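Benzyl on the ring nitrogen: a second instance

The source may report more compounds than this note shows. Statements on the series, on what has been measured and on what is new or still open speak of the compounds shown alone.

Measured in an assay on cells for inhibition of Polyunsaturated fatty acid 5-lipoxygenase (Rattus norvegicus), tested at 5 uM; a lower number here means less inhibition, a higher number more inhibition at the concentration tested (going by the name of the read-out):
compound 1 `COc1ccc2[nH]c(C)c(CCCC(=O)N3CCN(C(=O)OC(C)(C)C)CC3)c2c1` gives 71.2%
compound 2 `COc1ccc2c(c1)c(CCCC(=O)N1CCN(C(=O)OC(C)(C)C)CC1)c(C)n2Cc1ccccc1` gives 51.5%
compound 3 `COC1(c2cc(F)cc(OCCc3c[nH]c4ccccc34)c2)CCOCC1` gives 64.2%

Compound 2 is compound 1 with benzyl in place of hydrogen on an aromatic nitrogen, and this gave a number 19.7 percentage points lower from compound 1 to compound 2 (beyond the scatter). Compound 4 `COC1(c2cc(F)cc(OCCc3cn(Cc4ccccc4)c4ccccc34)c2)CCOCC1` is compound 3 with benzyl in place of hydrogen on an aromatic nitrogen. The two changes are the same kind, not the same: in compound 1 the nitrogen is next to the ring atom that bears a methyl group, which the place in compound 3 lacks. How the core of compound 3 differs from that of compound 1 is not broken down here. Compound 3 and compound 1 lie within the scatter of each other; compound 3 stands beyond the scatter above compound 2.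

Compound 4 is expected to give 45%, with a range of 25% to 65%. The step is expected to be a number 19.2 percentage points lower from compound 3 to compound 4 (beyond the scatter). Among the measured compounds shown here, this rests on the single measured instance, because a number 19.7 percentage points lower from compound 1 to compound 2 (beyond the scatter) is the only guide, and no second core shows whether the drop carries over.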

Compound 4, a percentage reported as inhibition, at one concentration (the size of the read-out at that concentration, not a potency): 31.8%
The estimate for compound 4 lay 13.2 percentage points above the measured number; low and high end bracket the measured number.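

In this assay, benzyl in place of hydrogen on an aromatic nitrogen again lowers the number, giving a number 32.4 percentage points lower from compound 3 to compound 4 (beyond the scatter). The drop therefore appears on both cores, and its size does not differ between them: the same change on two cores in this assay, a number 19.7 percentage points lower (beyond the scatter) from compound 1 to compound 2 and a number 32.4 percentage points lower (beyond the scatter) from compound 3 to compound 4, 12.7 percentage points apart, within the scatter of two such steps. Two cores support carrying this change over within this series, but they do not establish a rule for other cores or explain the drop.

Going by these compounds, it remains open whether the drop is specific to benzyl or would also follow from another group on that nitrogen, such as ethyl or a chain ending in a carboxylic acid. Also open, on these data alone, is whether an amine on the benzyl ring would change the size of the step.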